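The compounds below may be only part of what the source reports. "The series", "measured", "known", "first", "only" and "open" are said of these compounds alone.

Measured so far:
compound 1 `CC(C)Cc1ccc(C(C)c2n[nH]c(=S)n2N)cc1`: 16100 nM
compound 2 `CC(c1ccc(-c2ccccc2)c(F)c1)c1nnc2n1N=C(c1ccc(Cl)cc1Cl)CS2`: 7600 nM

In a functional assay on MCF7 cells (Homo sapiens) for inhibition, read by sulforhodamine B assay, with a stated time of 72 h (on this read-out lower numbers stand for stronger inhibition and higher numbers for weaker inhibition), compound 2 stands at the lower of the two numbers, and compound 1 lies beyond the scatter from it. For the measured compounds named here, with only two compounds, no trend across the series can be drawn.

Compound 3 `CC(c1ccc(-c2ccccc2)c(F)c1)c1nnc2n1N=C(c1ccc([N+](=O)[O-])cc1)CS2` remains to be measured. It differs from compound 2 in one place: 4-nitrophenyl in place of 2,4-dichlorophenyl on a carbon with a double bond to nitrogen. Going by the values given here, no measured pair in this set shows this exchange, so its effect has not been observed here and must be guessed.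

The expected step of a 1.3-fold higher number from compound 2 to compound 3 (0.12 log units; within the scatter) is small, roughly within the usual scatter, with a slight lean toward a weaker number. Compound 3 is therefore estimated at 10000 nM in this assay, with a plausible range from 3000 nM to 30000 nM.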

Compound 3, half-maximal inhibitory concentration: 7800 nM
Compound 3: the middle estimate sits 1.3-fold (0.11 log units) above what was measured, within the range that was stated.
By their numbers in this assay, from the lowest: compounds 2 and 3 (each within the scatter of the next); then compound 1.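

In this assay, 4-nitrophenyl in place of 2,4-dichlorophenyl on the carbon with a double bond to nitrogen gives a 1.0-fold higher number from compound 2 to compound 3 (0.01 log units; within the scatter), the first exchange read directly at this position. For this pair, the two chlorine atoms can leave and a nitro group can enter the aromatic ring without moving the number beyond the scatter, so the two aryl groups cannot be told apart on this read-out. Nothing available accounts for this match between the two groups.

For the compounds shown here, the single pair leaves open whether the position stays this insensitive across other groups, such as a plain phenyl or a phenyl ring carrying an amine or a carboxylic acid. It also leaves open whether any exchange at this position can move the number beyond the scatter in either direction.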